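Removing the para-fluoro from compound 3: an expected small step

This account rests on a few compounds, and the source may have more. Where it says the series, first, only, none or still open, it means among the compounds named here.

Three close analogues sharing one core have been measured. Compound 1 `Cc1ccc(CSc2nc3nc(C)cc(Nc4cc(-c5ccccc5)[nH]n4)n3n2)cc1` gives 7290 nM in a functional assay on MCF7 cells (Homo sapiens) for inhibition, read by MTT assay, with a stated time of 72 h; on this read-out lower numbers stand for stronger inhibition and higher numbers for weaker inhibition. Compound 2 `Cc1cc(Nc2cc(-c3cccs3)[nH]n2)n2nc(SCc3ccc(Br)cc3)nc2n1` gives 5370 nM in this assay, and compound 3 `Cc1cc(Nc2cc(-c3ccc(F)cc3)[nH]n2)n2nc(SCc3ccc(Br)cc3)nc2n1` gives 4570 nM. Among the measured compounds shown here, the only one-place step among them, a 1.2-fold lower number from compound 2 to compound 3 (0.07 log units; within the scatter), is within the scatter, and compound 3 does not separate from compound 1 or compound 2 beyond the scatter either, so the three stand together rather than in a ranked order.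

Compound 4 `Cc1cc(Nc2cc(-c3ccccc3)[nH]n2)n2nc(SCc3ccc(Br)cc3)nc2n1` differs from compound 3 by hydrogen in place of fluoro on an aromatic carbon of a six-membered aromatic ring of carbon only. For the measured compounds named here, no measured pair isolates this change. Compound 1 also carries a phenyl group, but it differs from compound 4 in a second place as well, so its value only shows that a phenyl-bearing member of the series sits in the same region as the others. Going by the values given here, the one measured step at this position, from thiophen-2-yl to 4-fluorophenyl, moved the number little, which suggests the ring is tolerant of variation here.

The expectation for compound 4 is therefore a step of a 1.2-fold higher number from compound 3 to compound 4 (0.08 log units; within the scatter), within the scatter, and an estimated value of 5500 nM in this assay, ranging from 2700 nM to 11000 nM.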

Compound 4, half-maximal inhibitory concentration: 2720 nM
Compound 4: middle estimate off by 2.0-fold (0.31 log units), on the high side; measured number inside the range.
By their numbers in this assay, from the lowest: compounds 4, 3, 2 and 1 (each within the scatter of the next, the first and the last beyond it).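

In this assay, the fluoro on the phenyl ring now has a direct reading: taking it away gives a step (a 1.7-fold lower number from compound 3 to compound 4 (0.23 log units; within the scatter)) that does not leave the scatter, so compound 3 and compound 4 cannot be told apart and the fluoro is not shown to matter here. Phenyl in place of thiophen-2-yl (a 2.0-fold lower number from compound 2 to compound 4 (0.30 log units; within the scatter)) also stays inside the scatter, which, together with the earlier step between the same two groups' neighbours, leaves thiophen-2-yl, 4-fluorophenyl and phenyl standing level at this position while bromo is held fixed. Among the compounds shown here, compound 4 also supplies the first pair that isolates a second place in the molecule: bromo in place of methyl (a 2.7-fold lower number from compound 1 to compound 4 (0.43 log units; beyond the scatter)) is the only step so far beyond the scatter, though modest, so in this small set the numbers separate there and not at the aromatic group.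

The compounds shown leave open whether this level picture holds for groups of another kind at the same place, such as an amine or a carboxylic acid on the phenyl ring, and whether chloro or a longer chain in the second place would widen the modest gap. Nothing available gives a reason for any of these numbers.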